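Amide aryl swap on a shared core: pyridin-2-yl

The source may report more compounds than this note shows. Statements on the series, on what has been measured and on what is new or still open speak of the compounds shown alone.

Notes on the series. Compound 1 `O=C(Nc1ccc(Cl)c(-c2nnc3c(Cl)cccn23)c1)c1ccc(C(F)(F)F)cc1Cl` and compound 2 `O=C(Nc1ccc(Cl)c(-c2nnc3c(Cl)cccn23)c1)c1ccc(F)cc1Cl` share one core and differ only in the ring on the carbonyl carbon. In a functional assay on T47D cells (Homo sapiens) for antiproliferative activity, read by MTT assay, with a stated time of 72 h (on this read-out higher numbers stand for weaker inhibition and lower numbers for stronger inhibition), compound 1 gives > 100000 nM, which is a limit of the assay and not a number. In this assay compound 2 likewise gives > 100000 nM, again a limit. The change from compound 1 to compound 2 is fluoro in place of trifluoromethyl on an aromatic carbon, and a step that the two limits leave unreadable from compound 1 to compound 2; the two limits leave its size unreadable. Compound 2 thus stands only at a limit on the numbers shown. The evidence on the measured values amounts to the limit of > 100000 nM in this assay, at which 2 of the 2 values shown sit.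

Compound 3 `O=C(Nc1ccc(Cl)c(-c2nnc3c(Cl)cccn23)c1)c1ccccn1` differs from compound 2 in the group on the carbonyl carbon: pyridin-2-yl in place of 2-chloro-4-fluorophenyl on a carbonyl carbon. Among the compounds with values here, no measured step covers an exchange of the ring itself; the only step measured, from compound 1 to compound 2, is unreadable and gives no direction. Nothing in the measured values points to a gain beyond the scatter, so the expected step of a number no higher from compound 2 to compound 3 (the limit leaves the size open) is set near zero. For compound 3 in this assay the estimate is 100000 nM, within 20000 nM to 300000 nM, most likely reported again as a limit.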

Compound 3, half-maximal inhibitory concentration: > 100000 nM
Compound 3: only a limit was reported (the forecaster's own chance of this, stated with the estimate: 65%); the middle value sits exactly at the limit.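

In this assay compound 3 gives > 100000 nM, a limit of the assay and not a number. Compound 2 and compound 3 both stand at a limit, and no step between them can be read: the limit of > 100000 nM in this assay, at which 3 of the 3 values shown sit.

The compounds shown leave open whether any group on the carbonyl carbon of the shared core can give a measurable value in this assay.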